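A few compounds are considered here, and "the series" means these few. Any claim that something is new, unique, unknown or untested is made for them only; others in the source may bear on it.

Compound 1 `Cc1cc(C)cc(NC(=O)NCCNS(=O)(=O)c2ccc(-c3ccccc3Oc3ccc([N+](=O)[O-])c([N+](=O)[O-])c3)s2)c1`: 9100 nM
Compound 2 `Cc1cc(C)cc(NC(=O)NCCNS(=O)(=O)c2ccc(-c3ccccc3OCc3ccccc3)s2)c1`: 2200 nM
Compound 3 `O=C(NCCNS(=O)(=O)c1cc(-c2ccccc2Oc2ccc(O)c(O)c2)cs1)Nc1cc(Cl)cc(Cl)c1`: > 20000 nM

These values come from a functional assay on HL-60 cells (Homo sapiens) for inhibition, read by CCK-8 assay, with a stated time of 48 h; on this read-out lower numbers stand for stronger inhibition and higher numbers for weaker inhibition. Among the two true numbers, the higher belongs to compound 1, at 9100 nM. The entry for compound 3, > 20000 nM, is a limit and not a number.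

Compound 4 `COc1cccc(NC(=O)NCCNS(=O)(=O)c2ccc(-c3ccccc3Oc3ccc([N+](=O)[O-])c([N+](=O)[O-])c3)s2)c1` keeps the rest of compound 1 and changes one group, with 3-methoxyphenyl in place of 3,5-dimethylphenyl on an amide-type nitrogen.

Within the data shown here, the only measured step, a 4.1-fold lower number from compound 1 to compound 2 (0.62 log units; beyond the scatter), put benzyl in place of 3,4-dinitrophenyl on an oxygen on an aromatic ring. Among the measured compounds shown here, that is a different place, so it gives neither size nor direction for this change, and no measured step alters the group on the amide-type nitrogen alone. The starting point is therefore compound 1 at 9100 nM, and no shift beyond the scatter is expected in this assay.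

The expected change is a 1.1-fold lower number from compound 1 to compound 4 (0.06 log units; within the scatter). The estimated value for compound 4 is 8000 nM, with an expected range of 3000 nM to 20000 nM.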

Compound 4, half-maximal inhibitory concentration: 6700 nM
For compound 4 the middle estimate is 1.2-fold (0.08 log units) above the measured one, and the stated range covers the measured number.
By their numbers in this assay, from the lowest: compound 2; then compounds 4 and 1 (each within the scatter of the next). At a limit, above all of these: compound 3.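

Among these compounds, replacing 3,5-dimethylphenyl with 3-methoxyphenyl on the amide-type nitrogen gives a 1.4-fold lower number from compound 1 to compound 4 (0.13 log units; within the scatter) in this assay, the first measured change at this position. Within this pair, the two groups cannot be told apart, even though one methyl-bearing ring gives way to a ring carrying an oxygen and the count of heavy atoms stays the same. Nothing measured here gives a reason why the two groups read alike.

As far as these compounds go, this comparison rests on a single pair with 3,4-dinitrophenyl on the oxygen, so whether the two groups also match with benzyl there, as in compound 2, remains open. Also open, from the compounds shown here alone, is how a markedly different group on this nitrogen would read, such as a pyridine ring, a carboxylic acid on the phenyl ring or a longer chain ending in an amine.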